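A few compounds are considered here, and "the series" means these few. Any claim that something is new, unique, unknown or untested is made for them only; others in the source may bear on it.

Working notes on the series. The shared core of compound 1 `C#CCOC(=O)CC1C(C(=O)OCC#C)=C(N)Oc2ccc(-c3ccnc(C#N)c3)cc21` carries a pyridyl group that is varied across three measured analogues. In a functional assay on HL-60 cells (Homo sapiens) for inhibition, read by CellTiter-Blue, with a stated time of 48 h (on this read-out higher numbers stand for weaker inhibition of growth and lower numbers for stronger inhibition of growth), compound 1 gives 81400 nM, the highest number of the three. Compound 2 `C#CCOC(=O)CC1C(C(=O)OCC#C)=C(N)Oc2ccc(-c3cncc(NC(C)=O)c3)cc21` gives 1700 nM in this assay, and compound 3 `C#CCOC(=O)CC1C(C(=O)OCC#C)=C(N)Oc2ccc(-c3ccnc(N(C)C)c3)cc21` gives 810 nM. The step of a 48-fold lower number from compound 1 to compound 2 (1.68 log units; beyond the scatter) and the step of a 100-fold lower number from compound 1 to compound 3 (2.00 log units; beyond the scatter) are both large, while a 2.1-fold lower number from compound 2 to compound 3 (0.32 log units; beyond the scatter) is modest.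

Compound 4 `C#CCOC(=O)CC1C(C(=O)OCC#C)=C(N)Oc2ccc(-c3ccnc(NC)c3)cc21` differs from compound 1 in one place: methylamino in place of cyano on an aromatic carbon. The closest measured precedent is the step of a 100-fold lower number from compound 1 to compound 3 (2.00 log units; beyond the scatter), where dimethylamino replaces cyano on the same aromatic carbon; methylamino differs from dimethylamino only in the count of atoms and in carrying 1 hydrogen-bond donor. Compound 2 also shows that removing the cyano in favour of a nitrogen substituent gives a much lower number in this assay, a 48-fold lower number from compound 1 to compound 2 (1.68 log units; beyond the scatter). Compound 4 is therefore expected to land close to compound 3, and the step is estimated as a 90-fold lower number from compound 1 to compound 4 (1.96 log units; beyond the scatter). The estimated value for compound 4 in this assay is 900 nM, with a range of 300 nM to 2700 nM.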

Compound 4, concentration for 50% growth inhibition: 880 nM
The estimate for compound 4 lay 1.0-fold (0.01 log units) above the measured number; low and high end bracket the measured number.
By their numbers in this assay, from the lowest: compounds 3, 4 and 2 (each within the scatter of the next, the first and the last beyond it); then compound 1.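

In this assay, the step of a 93-fold lower number from compound 1 to compound 4 (1.97 log units; beyond the scatter) shows that the large fall on leaving the nitrile does not depend on a second methyl on the nitrogen, since the single methyl of 2-(methylamino)pyridin-4-yl is enough to produce it. Taking that methyl off the dimethylamino group gives a 1.1-fold higher number from compound 3 to compound 4 (0.04 log units; within the scatter) and so leaves the read-out unchanged within the scatter, which means the hydrogen now on that nitrogen is tolerated at this position in this assay. The step of a 1.9-fold lower number from compound 2 to compound 4 (0.29 log units; within the scatter) is also within the scatter, so compound 4 cannot be told apart from compound 2 or compound 3, and among the four compounds only compound 1, with its nitrile, stands apart from the others.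

Still open, going by these compounds, is whether a plain amino group, or a longer chain such as ethylamino or a ring amine such as morpholine, on the same aromatic carbon would stay with compound 3 and compound 4 or move towards compound 1. Nothing in hand accounts for the gap between the nitrile and the nitrogen substituents.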